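From compound 3 to its single enantiomer compound 4

The source may hold more compounds than are shown below. What is called first, only, known or untested is meant among the compounds shown, and "the series" means these compounds.

Compound 3 `CCCC(C(N)=O)C(C)C` gives 50 mg/kg in a functional assay on the whole organism (strain Sprague-Dawley) with Rattus norvegicus as the target, in the maximal electroshock model (on this read-out lower numbers stand for an effect already at smaller amounts and higher numbers for an effect only at larger amounts of compound), the highest of the three numbers measured. Within the data shown here, compound 1 `CCC[C@@H](C(N)=O)C(C)C`, drawn with the R configuration, gives 47 mg/kg, and compound 2 `CCC[C@H](C(=O)NC(N)=O)C(C)C` gives 18 mg/kg; the gap between compound 3 and compound 2 lies beyond the scatter, while the step of a 1.1-fold higher number from compound 1 to compound 3 (0.03 log units; within the scatter) does not, the only change there being (the fact that one of compounds 1 and 3 is drawn with a defined configuration and the other without, at the place where they differ). Compound 4 `CCC[C@H](C(N)=O)C(C)C` differs from compound 3 by the two compounds have the same atoms and bonds; at least one stereo element is drawn with a configuration in one of them and without one in the other: 1 of 1 stereo elements differ; a stereocentre at a saturated chain carbon is drawn without a configuration in compound 3 and S in compound 4. Since drawing one configuration in place of none gave no step beyond the scatter between compound 1 and compound 3, no step beyond the scatter is expected here either. Compound 4 is therefore estimated at 50 mg/kg, between 25 mg/kg and 100 mg/kg, an expected step of no change at the digits printed from compound 3 to compound 4 (within the scatter).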

Compound 4, dose for half-maximal effect: 63 mg/kg
Compound 4: middle estimate off by 1.3-fold (0.10 log units), on the low side; the measured number falls inside the stated range.
By their numbers in this assay, from the lowest: compound 2; then compounds 1, 3 and 4 (each within the scatter of the next).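

With compound 4, both drawn configurations of this stereocentre can be compared in this assay, and swapping one for the other stays within the scatter (a 1.3-fold higher number from compound 1 to compound 4 (0.13 log units; within the scatter)). Defining the centre as S likewise gives no step beyond the scatter (a 1.3-fold higher number from compound 3 to compound 4 (0.10 log units; within the scatter)). Only the carbamoyl group on the amide-type nitrogen separates compound 4 from compound 2, and that step lies beyond the scatter (a 3.5-fold higher number from compound 2 to compound 4 (0.54 log units; beyond the scatter)). Still open, going by these compounds, is whether configuration matters when that carbamoyl group is present. Also open, on these data alone, is how a longer chain or a carboxylic acid would fare in this assay.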